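Moving two chlorines on an amide aryl group

A few compounds are considered here, and "the series" means these few. Any claim that something is new, unique, unknown or untested is made for them only; others in the source may bear on it.

Values in a functional assay on Vero cells (Chlorocebus sabaeus) for inhibition (on this read-out higher numbers stand for weaker inhibition and lower numbers for stronger inhibition), so far:
compound 1 `COc1cc(/C=C/C(=O)c2cccc(NC(=O)c3c(Cl)cccc3Cl)c2)ccc1O` gives 2.48 ug/mL
compound 2 `COc1cc(/C=C/C(=O)c2cccc(NC(=O)c3ccco3)c2)ccc1O` gives 3.11 ug/mL
compound 3 `COc1cc(/C=C/C(=O)c2cccc(N)c2)ccc1O` gives 6.02 ug/mL

Compound 1 stands at the low end of these three numbers, level within the scatter with compound 2. Only its gap to compound 3 goes beyond the scatter. Compound 4 `COc1cc(/C=C/C(=O)c2cccc(NC(=O)c3ccc(Cl)cc3Cl)c2)ccc1O` has yet to be measured in this assay and differs from compound 1 by 2,4-dichlorophenyl in place of 2,6-dichlorophenyl on a carbonyl carbon. Within the data shown here, no measured step moves a chlorine, so the evidence is indirect. Replacing the whole group gave a 1.3-fold higher number from compound 1 to compound 2 (0.10 log units; within the scatter) as a result, and removing the whole acyl unit gave a 2.4-fold higher number from compound 1 to compound 3 (0.39 log units; beyond the scatter) as a modest result. The same removal from the furan amide gave a 1.9-fold higher number from compound 2 to compound 3 (0.29 log units; within the scatter) as its result. A swap between two isomeric groups is therefore expected to leave no change beyond the scatter. The expected outcome is a 1.1-fold higher number from compound 1 to compound 4 (0.05 log units; within the scatter) at most a slight drift. For compound 4 the estimated value is 2.8 ug/mL with an expected range from 1.5 ug/mL to 5 ug/mL in this estimate.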

Compound 4, half-maximal inhibitory concentration: 27.2 ug/mL
The estimate for compound 4 lay 9.7-fold (0.99 log units) below the measured number, and the stated range ends below it.
By their numbers in this assay, from the lowest: compounds 1, 2 and 3 (each within the scatter of the next, the first and the last beyond it); then compound 4.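

In this assay, the arrangement of the two chlorines on the aryl group weighs far more than their presence: the swap of 2,6-dichlorophenyl for 2,4-dichlorophenyl on the carbonyl carbon gives an 11-fold higher number from compound 1 to compound 4 (1.04 log units; beyond the scatter), although both groups hold the same atoms. The 2,4-dichlorophenyl amide also stands behind the free amine, with a 4.5-fold higher number from compound 3 to compound 4 (0.65 log units; beyond the scatter), and behind the furan amide, with an 8.7-fold higher number from compound 2 to compound 4 (0.94 log units; beyond the scatter), so acylating this nitrogen does not by itself bring a lower number. Nothing available here accounts for this shift.

The compounds shown leave open whether a phenyl group carrying a single chlorine would stay level with compound 1 or move towards compound 4. They also leave open how methyl or methoxy groups in place of the chlorines would read.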